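Replacing a Pyrazole with a Small Amide on a Shared Core

The source may hold more compounds than are shown below. What is called first, only, known or untested is meant among the compounds shown, and "the series" means these compounds.

Compound 1 `Cn1ccc(-c2cccc3c2CCC3c2ncc[nH]2)n1`: > 1300 nM
Compound 2 `CCS(=O)(=O)Nc1cccc(Cc2c[nH]cn2)c1`: 9 nM
Compound 3 `Clc1ccc2c(c1-c1ccn[nH]1)CCC2c1ncc[nH]1`: 322 nM

In a functional assay on CHO cells for agonist activity at Alpha-1A adrenergic receptor (Homo sapiens), read by FLIPR and calcium flux (on this read-out lower numbers stand for an effect already at smaller amounts and higher numbers for an effect only at larger amounts of compound), compound 1 reaches only the limit of the assay, > 1300 nM, so no number is known for it (the limit of > 1300 nM in this assay, at which 1 of the 3 values shown sits). In this assay compound 2 gives 9 nM and compound 3 gives 322 nM; neither shares a single-point change with compound 1.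

Compound 4 `CNC(=O)c1cccc2c1CCC2c1ncc[nH]1` differs from compound 1 in one place: methylcarbamoyl in place of 1-methyl-1H-pyrazol-3-yl on an aromatic carbon. Among the measured compounds shown here, no measured pair shows what this change does, and since compound 1 sits at a limit, the step cannot be pinned down in this assay. Compound 4 is expected to land near the weaker end of the measured compounds, with an at least 1.6-fold lower number from compound 1 to compound 4 (0.21 log units; that floor lies within the scatter) as the guess; the estimate for compound 4 is 800 nM, within 150 nM to 4000 nM.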

Compound 4, half-maximal effective concentration: 2200 nM
Estimate against measurement, compound 4: 2.8-fold (0.44 log units) below; the range from low to high includes it.
By their numbers in this assay, from the lowest: compound 2; then compound 3; then compound 4.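

The value of compound 1 is only a limit, so the step from compound 1 to compound 4 cannot be read: (the limit of > 1300 nM in this assay, at which 1 of the 4 values shown sits). As far as these compounds go, what remains open is how far methylcarbamoyl in place of 1-methyl-1H-pyrazol-3-yl on the shared core moves the number in this assay for this pair.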